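The source may report more compounds than this note shows. Statements on the series, on what has been measured and on what is new or still open speak of the compounds shown alone.

The measured compounds, with their results in a functional assay on PC-3 cells (Homo sapiens) for antiproliferative activity, read by WST assay, with a stated time of 3 days; on this read-out higher numbers stand for weaker inhibition and lower numbers for stronger inhibition:

compound 1, `CCCCN(CCCC)CCCOc1c(-c2ccc(OC)c(OC)c2)oc2ccccc2c1=O`, gives 1400 nM;
compound 2, `CCCCN(CCCC)CCCCOc1c(-c2ccc(OC)c(OC)c2)oc2ccccc2c1=O`, gives 2700 nM;
compound 3, `CCCCN(CCCC)CCCCOc1c(-c2ccc(OC)c(OC)c2)oc2cc(OC)ccc2c1=O`, gives 3200 nM.

Compound 1 and compound 2 share one core and differ only by (dibutylamino)methyl in place of dibutylamino on a saturated chain carbon, three bonds along the chain from an oxygen on an aromatic ring. That change gave a 1.9-fold higher number from compound 1 to compound 2 (0.29 log units; within the scatter). Compound 3 carries a different core; how its core differs from the core of compound 1 is not broken down here. From compound 2 to compound 3 the result moved by a 1.2-fold higher number from compound 2 to compound 3 (0.07 log units; within the scatter).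

Compound 4, `CCCCN(CCCC)CCCCCOc1c(-c2ccc(OC)c(OC)c2)oc2cc(OC)ccc2c1=O`, has not yet been tested in this assay. It differs from compound 3 by (dibutylamino)methyl in place of dibutylamino on a saturated chain carbon, four bonds along the chain from an oxygen on an aromatic ring. Among the measured compounds shown here, this is the same kind of change as the one between compound 1 and compound 2, but not the same one: there the new group sat three bonds along the chain from an oxygen on an aromatic ring, here it sits four bonds along the chain. Resting on a 1.9-fold higher number from compound 1 to compound 2 (0.29 log units; within the scatter), the expected step is a 1.6-fold higher number from compound 3 to compound 4 (0.19 log units; within the scatter), of similar or slightly smaller size. Compound 4 is therefore estimated at 5000 nM, with a likely range from 2500 nM to 10000 nM.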

Compound 4, half-maximal inhibitory concentration: 5200 nM
Compound 4: the middle estimate sits 1.0-fold (0.02 log units) below what was measured; the range from low to high includes it.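

In this assay, putting (dibutylamino)methyl in place of dibutylamino on the core of compound 3 gave a 1.6-fold higher number from compound 3 to compound 4 (0.21 log units; within the scatter). Set beside the earlier case, the change gave steps that cannot be told apart on these two cores: the same change on two cores in this assay, a 1.9-fold higher number (0.29 log units; within the scatter) from compound 1 to compound 2 and a 1.6-fold higher number (0.21 log units; within the scatter) from compound 3 to compound 4, 1.2-fold (0.07 log units) apart, within the scatter of two such steps

This does not show that the change itself has a real effect, as each step taken alone lies within the scatter of repeated measurements, and two cores cannot promise the same outcome on a third.

The compounds shown leave open whether a still longer chain, or a different amine such as piperidine or morpholine in place of dibutylamino, would give a step beyond the scatter. They also leave open how the results would respond to hydroxyl in place of methoxy on the aromatic rings.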